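Methoxy pattern on the aryl ring and cytotoxicity readout

A few compounds are considered here, and "the series" means these few. Any claim that something is new, unique, unknown or untested is made for them only; others in the source may bear on it.

Compound 1 `COc1ccc(-c2cc(/C=C/C(=O)c3ccc(N)cc3)[nH]n2)cc1` and compound 2 `COc1cc(-c2cc(/C=C/C(=O)c3ccc(N)cc3)[nH]n2)cc(OC)c1OC` share a core and differ only in the methoxy pattern on the ring that hangs from it. In a functional assay on HOP-62 cells (Homo sapiens) for cytotoxicity, read by sulforhodamine B assay, with a stated time of 48 h, tested at 10 uM (on this read-out higher numbers stand for a weaker effect at the one concentration tested and lower numbers for a stronger effect), compound 1 gives -15%, while compound 2 gives -59%. For the measured compounds named here, of the two numbers measured so far, compound 2 stands lowest; the gap to compound 1 lies beyond the usual scatter, so compound 2 is the stronger of the pair on this read-out.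

Compound 3 `COc1ccc(-c2cc(/C=C/C(=O)c3ccc(N)cc3)[nH]n2)cc1OC` has not been measured yet. Relative to compound 2 the change is hydrogen in place of methoxy on an aromatic carbon. Going by the values given here, no step between measured compounds that covers this single change is available, so the expectation rests on where compound 1 and compound 2 stand. Removing one of the methoxy groups moves compound 3 toward the pattern of compound 1, and the number is therefore expected to rise, that is, a weaker effect, with a step of a number 24 percentage points higher from compound 2 to compound 3 (beyond the scatter) that is estimated to exceed the scatter. For compound 3 in this assay the estimate is -35%, with a range from -70% to 0%.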

Compound 3, a percentage reported as activity, at one concentration (the size of the read-out at that concentration, not a potency): -1%
Estimate against measurement, compound 3: 34 percentage points below; the range from low to high includes it.
By their numbers in this assay, from the lowest: compound 2; then compound 1; then compound 3.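

In this assay, the methoxy on this aromatic carbon, ortho to a methoxy group and meta to both a large group and a second methoxy group, carries a large share of the effect: replacing it with hydrogen gives a number 58 percentage points higher from compound 2 to compound 3 (beyond the scatter), leaving compound 3 the weakest of the three on this read-out. The same kind of change does not act in one direction across the series, since methoxy in place of hydrogen gives a number 14 percentage points higher from compound 1 to compound 3 (beyond the scatter), a modest weakening, whereas the methoxy present in compound 2 but absent from compound 3 goes with a stronger effect, so the number of methoxy groups alone does not order these compounds. No measurement at hand bears on why this step is large or why the two methoxy changes run in opposite directions.

The compounds shown leave open whether the methoxy itself is needed at this carbon or whether a hydroxy group, a chlorine atom or an ethoxy group would serve equally well. They also leave open whether the opposite directions of the two steps would hold in other cell lines or at other concentrations.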